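Trifluoromethyl to Methyl on the Sulfonyl Group

This account rests on a few compounds, and the source may have more. Where it says the series, first, only, none or still open, it means among the compounds named here.

Of the compounds shown here, three built on one shared core have been tested in an assay for inhibition of Apoptosis regulator Bcl-2 (Homo sapiens), read by fluorescence polarization, with a stated time of 2 h; on this read-out lower numbers stand for stronger inhibition and higher numbers for weaker inhibition. Compound 1 `Cc1c(C(=O)NCCCN2CCN(C)CC2)c(-c2cccc(N3CCN(c4ccc(NS(=O)(=O)c5cccc(OC(F)(F)F)c5)cc4)CC3)c2)c(-c2ccc(Cl)cc2)n1C` gives 763 nM in this assay. Compound 2 `CCOc1cccc(S(=O)(=O)Nc2ccc(N3CCN(c4cccc(-c5c(C(=O)NCCCN6CCN(C)CC6)c(C)n(C)c5-c5ccc(Cl)cc5)c4)CC3)cc2)c1` gives 1620 nM in this assay. Compound 3 `Cc1c(C(=O)NCCCN2CCN(C)CC2)c(-c2cccc(N3CCN(c4ccc(NS(=O)(=O)c5cccc(S(=O)(=O)C(F)(F)F)c5)cc4)CC3)c2)c(-c2ccc(Cl)cc2)n1C` gives 153 nM in this assay, the lowest of the three numbers: the other two compounds stand further up, as shown by a 5.0-fold lower number from compound 1 to compound 3 (0.70 log units; beyond the scatter) and an 11-fold lower number from compound 2 to compound 3 (1.02 log units; beyond the scatter).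

Compound 4 `Cc1c(C(=O)NCCCN2CCN(C)CC2)c(-c2cccc(N3CCN(c4ccc(NS(=O)(=O)c5cccc(S(C)(=O)=O)c5)cc4)CC3)c2)c(-c2ccc(Cl)cc2)n1C` has not yet been measured. It differs from compound 3 in one place: methyl in place of trifluoromethyl on a sulfonyl sulfur. Among the compounds with values here, no measured step changes the group on the sulfonyl sulfur itself, so the closest guide is the one step that exchanges a fluorinated alkyl for a plain alkyl, there on an oxygen: that exchange gave a 2.1-fold higher number from compound 1 to compound 2 (0.33 log units; beyond the scatter). The two steps that bring in the (trifluoromethyl)sulfonyl group both lowered the number, but they do not separate the part played by the fluorines from that of the sulfonyl. A modest rise in this assay is therefore expected for compound 4, namely a 2.6-fold higher number from compound 3 to compound 4 (0.42 log units; beyond the scatter). The estimate for compound 4 is 400 nM, with a range from 150 nM to 1100 nM.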

Compound 4, half-maximal inhibitory concentration: 2540 nM
Compound 4: middle estimate off by 6.4-fold (0.80 log units), on the low side; measured number above the stated range.
By their numbers in this assay, from the lowest: compound 3; then compound 1; then compounds 2 and 4 (each within the scatter of the next).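

In this assay, the change from trifluoromethyl to methyl on a sulfonyl sulfur gives a large step (a 17-fold higher number from compound 3 to compound 4 (1.22 log units; beyond the scatter)), much larger than the exchange of trifluoromethyl for ethyl on an oxygen (a 2.1-fold higher number from compound 1 to compound 2 (0.33 log units; beyond the scatter)). Within the data shown here, this separates what the earlier steps could not: the low number of compound 3 depends on the trifluoromethyl on the sulfonyl sulfur, and a sulfonyl on the aromatic carbon does not bring it alone. Methylsulfonyl is no gain over the two oxygen-linked groups, since its step from the ethoxy compound stays within the scatter (a 1.6-fold higher number from compound 2 to compound 4 (0.20 log units; within the scatter)) and its step from the trifluoromethoxy compound goes the wrong way, to a higher number (a 3.3-fold higher number from compound 1 to compound 4 (0.52 log units; beyond the scatter)).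

From the compounds shown here alone, it remains open whether difluoromethyl, ethyl or pentafluoroethyl on the sulfonyl sulfur, or an amine such as dimethylamino in that place, would give a number closer to that of compound 3 or to that of compound 4. The data shown offer no measurement that explains the size of this step.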